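A few compounds are considered here, and "the series" means these few. Any claim that something is new, unique, unknown or untested is made for them only; others in the source may bear on it.

Compound 3 `COc1cc(-c2nn(-c3cccc(NC(=O)Nc4cccc(C(F)(F)F)c4)c3)cc2-c2ccncc2)ccc1Cl` stands at the edge of what a functional assay on NCI-H226 cells (Homo sapiens) for inhibition, read by sulforhodamine B assay, with a stated time of 48 h (on this read-out lower numbers stand for stronger inhibition of growth and higher numbers for weaker inhibition of growth), reports: in this assay compound 3 gives > 50000 nM, which is a limit of the assay and not a number. Compound 1 `O=C(Nc1cccc(-n2cc(-c3ccncc3)c(-c3ccc(Cl)c(O)c3)n2)c1)Nc1cccc(C(F)(F)F)c1` likewise gives only a limit, > 32500 nM. Compound 2 `COc1cc(-c2nn(-c3cccc(NC(=O)Nc4cc(C(F)(F)F)cc(C(F)(F)F)c4)c3)cc2-c2ccncc2)ccc1Cl` gives a measured 21800 nM. The step that the two limits leave unreadable from compound 1 to compound 3 therefore says little, while the step of an at least 2.2-fold higher number from compound 2 to compound 3 (0.36 log units; beyond the scatter) shows that taking a trifluoromethyl off that phenyl ring pushed the number up. Compound 4 `COc1cc(-c2nn(-c3cccc(NC(=O)Nc4ccc(Cl)c(C(F)(F)F)c4)c3)cc2-c2ccncc2)ccc1Cl` differs from compound 3 by chloro in place of hydrogen on an aromatic carbon, a change in the same ring. Given the step of an at least 2.2-fold higher number from compound 2 to compound 3 (0.36 log units; beyond the scatter), adding a substituent there is expected to lower the number again. Compound 4 is thus estimated at 25000 nM, within 10000 nM to 60000 nM, an expected step of an at least 2.0-fold lower number from compound 3 to compound 4 (0.30 log units; that floor lies within the scatter).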

Compound 4, concentration for total growth inhibition: > 32500 nM
Compound 4 was reported as a limit (the forecaster's own chance of this, stated with the estimate: 40%); middle value at least 1.3-fold (0.11 log units) from the limit.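

Compound 3 and compound 4 both give only a limit in this assay, not a number, and the step between them cannot be read. As far as these compounds go, whether chloro in place of hydrogen on that ring changes growth inhibition at all stays open.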